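From 3,4-dichlorophenyl to 4-nitrophenyl: what to expect

This account rests on a few compounds, and the source may have more. Where it says the series, first, only, none or still open, it means among the compounds named here.

Compound 1 `Nc1nc(N)c2cc(CSC(=S)N3CCN(C4CCCCC4)CC3)ccc2n1`: 4710 nM
Compound 2 `Nc1nc(N)c2cc(CSC(=S)N3CCN(c4ccc(Cl)c(Cl)c4)CC3)ccc2n1`: 2940 nM

In a functional assay on A549 cells (Homo sapiens) for antiproliferative activity, read by MTT assay, with a stated time of 72 h (on this read-out lower numbers stand for stronger inhibition and higher numbers for weaker inhibition), compound 2 gives 2940 nM, a value within the usual scatter of compound 1 at 4710 nM. Compound 3 `Nc1nc(N)c2cc(CSC(=S)N3CCN(c4ccc([N+](=O)[O-])cc4)CC3)ccc2n1` keeps the rest of compound 2 and changes one group: 4-nitrophenyl in place of 3,4-dichlorophenyl on an amine nitrogen in a ring. For the measured compounds named here, the only measured step at this place is a 1.6-fold lower number from compound 1 to compound 2 (0.20 log units; within the scatter), which stays within the scatter even though cyclohexyl gave way to 3,4-dichlorophenyl. One small step is thin evidence, but it gives no reason to expect a large move in this assay. The expected result is a 1.0-fold higher number from compound 2 to compound 3 (0.01 log units; within the scatter), with no clear direction. For compound 3 the estimate is 3000 nM, with an expected range of 1200 nM to 8000 nM.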

Compound 3, half-maximal inhibitory concentration: 1910 nM
Beside the measured number, compound 3's estimate is 1.6-fold (0.20 log units) above it; the measured number falls inside the stated range.
By their numbers in this assay, from the lowest: compounds 3, 2 and 1 (each within the scatter of the next, the first and the last beyond it).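

In this assay, swapping one aromatic group for the other shows a 1.5-fold lower number from compound 2 to compound 3 (0.19 log units; within the scatter) and so does not separate 4-nitrophenyl from 3,4-dichlorophenyl, although only 4-nitrophenyl carries hydrogen-bond acceptors. For the compounds shown here, the comparison with the non-aromatic group gives the first step at this position that clears the scatter, a 2.5-fold lower number from compound 1 to compound 3 (0.39 log units; beyond the scatter) for 4-nitrophenyl in place of cyclohexyl, and that step is modest. Nothing measured here explains either step.

Still open, going by these compounds, is whether a phenyl ring bearing an amine or a carboxylic acid would behave like these two aromatic groups. A longer chain between the ring nitrogen and the phenyl ring is also untested among the compounds shown.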